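The source may report more compounds than this note shows. Statements on the series, on what has been measured and on what is new or still open speak of the compounds shown alone.

Compound 1 `COC(=O)C1=C(C)NC(C)=C(C(=O)OC)C1c1ccccc1`: 28.2 nM
Compound 2 `COC(=O)C1=C(C)N=C(C)/C(=C(\O)OC)C1c1ccc(F)cc1`: 129 nM
Compound 3 `COC(=O)C1=C(C)N=C(C)/C(=C(/O)OC)C1c1cccc(Cl)c1`: 15.9 nM

Of the compounds shown here, three have so far been tested in a functional assay (muscle tissue) with Cavia porcellus as the target; on this read-out lower numbers stand for an effect already at smaller amounts and higher numbers for an effect only at larger amounts of compound. Compound 2 stands at the highest number of the three; compound 1 sits at a lower number and compound 3 at the lowest, and both gaps lie beyond the usual scatter. Compound 4 `COC(=O)C1=C(C)N=C(C)/C(=C(\O)OC)C1c1ccc(Br)cc1` has not yet been measured. It differs from compound 2 by bromo in place of fluoro on an aromatic carbon. Within the data shown here, no single-change step between measured compounds is available, so the weight of this swap cannot be read from the data. Compound 1, with no halogen on that ring, gives 28.2 nM, while compound 2 gives 129 nM, which hints that the halogen-bearing ring of compound 2 is not the best arrangement. Compound 4 is therefore expected to show a small shift toward a lower number, the expected step being a 1.6-fold lower number from compound 2 to compound 4 (0.21 log units; within the scatter). Compound 4 is estimated at 80 nM, within a range from 20 nM to 300 nM.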

Compound 4, half-maximal effective concentration: 540 nM
Compound 4: the middle estimate sits 6.8-fold (0.83 log units) below what was measured; measured number outside the range, above it.
By their numbers in this assay, from the lowest: compounds 3 and 1 (each within the scatter of the next); then compound 2; then compound 4.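

In this assay, among these compounds, going from 4-fluorophenyl to 4-bromophenyl gives a 4.2-fold higher number from compound 2 to compound 4 (0.62 log units; beyond the scatter), the only single-change reading available here. It shows that this place, on an aromatic carbon para to a large group, is sensitive to which halogen it carries: exchanging one heavy atom, with no change in hydrogen-bond donors, acceptors or net charge, moves the number beyond the scatter. Nothing measured here accounts for this shift.

Going by these compounds, whether chloro, methoxy or an amine at this place would give a lower number than compound 2 remains open. So does whether the same exchange would have a similar effect elsewhere on that ring.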